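This account rests on a few compounds, and the source may have more. Where it says the series, first, only, none or still open, it means among the compounds named here.

Measured compounds:
compound 1, `COc1ccc(NC(=O)CN2C(=O)NC3(C2=O)c2ccccc2-c2ccccc23)cc1`: <= 200%
compound 2, `O=C(CN1C(=O)NC2(C1=O)c1ccccc1-c1ccccc12)Nc1ccc(Cl)cc1Cl`: 84.3%
compound 3, `COc1ccc(NC(=O)CN2C(=O)NC3(CCCCC3)C2=O)cc1`: 56.1%

Of the compounds shown here, three have been measured in a functional assay on the whole organism (strain BALB/c) with Mus musculus as the target, with a stated time of 8 h, at a dose of 10 mg/kg; a lower number here means less inhibition, a higher number more inhibition at the dose given (going by the name of the read-out). For compound 1 the assay reports only a limit, <= 200%, and not a number. In this assay compound 2 gives 84.3%. Compound 1 and compound 2 differ in one place, (2,4-dichlorophenyl in place of 4-methoxyphenyl on an amide-type nitrogen), and the step between them is a step that the limit leaves unreadable from compound 1 to compound 2; its size is not readable because the limit of <= 200% in this assay, at which 1 of the 3 values shown sits, covers the value of compound 1.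

Compound 3 carries a different core; the difference between the two cores is not broken down here. In this assay compound 3 gives 56.1%, the lowest of the two numbers, and compound 2 sits higher by a gap beyond the scatter. Since these two compounds differ both in the core and in the aryl group, only their two values can be compared.

Compound 4, `O=C(CN1C(=O)NC2(CCCCC2)C1=O)Nc1ccc(Cl)cc1Cl`, has not yet been measured. It differs from compound 3 by 2,4-dichlorophenyl in place of 4-methoxyphenyl on an amide-type nitrogen, the same change as that from compound 1 to compound 2, with the same surroundings around the place. That earlier step left no readable size, so the expectation rests on compound 2 and its value 84.3%, which carries the entering group on the other core, and on compound 3 with 56.1%. Compound 4 is therefore expected to give about 65% in this assay, most likely between 40% and 90%. This estimate means an expected step of a number 8.9 percentage points higher from compound 3 to compound 4 (within the scatter).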

Compound 4, a percentage reported as inhibition, in the whole organism at one dose (the size of the read-out at that dose, not a potency): 68.5%
Compound 4: the middle estimate sits 3.5 percentage points below what was measured, and the stated range covers the measured number.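

In this assay, putting 2,4-dichlorophenyl in place of 4-methoxyphenyl on an amide-type nitrogen gives a number 12.4 percentage points higher from compound 3 to compound 4 (beyond the scatter), and this is the only readable size the change has in the series shown. On the other core the same change starts from compound 1, whose entry is only a limit, <= 200%. The step on that core cannot be read, so a single step on one core shows that the change can raise the read-out there, but it does not show that the change carries over from one core to the other or that its size is the same on both, because of this limit: the limit of <= 200% in this assay, at which 1 of the 4 values shown sits.

With 2,4-dichlorophenyl on both cores, compound 2 gives 84.3% and compound 4 gives 68.5%, which leaves open how the two cores compare with other groups on that nitrogen and at other doses or times. Also open, as far as these compounds go, is what a pyridine ring, a phenyl ring bearing a single chlorine, a carboxylic acid or an amine on the aryl ring, or a longer chain leading to the amide-type nitrogen would do on either core.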